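The source may hold more compounds than are shown below. What is called first, only, known or untested is meant among the compounds shown, and "the series" means these compounds.

Compound 1 `CC(C)Nc1sc(C(=O)c2ccc(Cl)s2)c(N)c1C#N` gives 192 nM in an assay for inhibition of Maternal embryonic leucine zipper kinase (Homo sapiens), read by ADP-Glo, with a stated time of 0.5 h; on this read-out higher numbers stand for weaker inhibition and lower numbers for stronger inhibition.
Compound 2 `CC(C)Nc1sc(C(=O)c2ccc(I)s2)c(N)c1C#N` gives 112 nM in this assay.

For the measured compounds named here, compound 1 carries the higher of the two numbers, but the only measured step, a 1.7-fold lower number from compound 1 to compound 2 (0.23 log units; within the scatter), stays within the scatter, so the two cannot be ordered. Compound 3 `CCNc1sc(C(=O)c2ccc(Cl)s2)c(N)c1C#N` differs from compound 1 by hydrogen in place of methyl on a saturated chain carbon bound to a nitrogen on an aromatic ring and a saturated chain carbon. Going by the values given here, no measured step touches the isopropylamino group; the single step available alters a halogen on the aromatic ring and does not bear on this change. Compound 3 is therefore expected to sit near compound 1, with an estimated step of a 1.3-fold higher number from compound 1 to compound 3 (0.11 log units; within the scatter) and an estimated value of 250 nM, between 100 nM and 650 nM.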

Compound 3, half-maximal inhibitory concentration: 222 nM
Estimate against measurement, compound 3: 1.1-fold (0.05 log units) above; low and high end bracket the measured number.
By their numbers in this assay, from the lowest: compounds 2, 1 and 3 (each within the scatter of the next).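

Going from isopropylamino to ethylamino is the first change shown at this position, and in this assay it gives a 1.2-fold higher number from compound 1 to compound 3 (0.06 log units; within the scatter). Removing this methyl from the saturated chain carbon therefore leaves compound 1 and compound 3 indistinguishable, which the halogen step on the aromatic ring could not show. No evidence is available on why this is so. The compounds shown leave open how a longer chain, a cyclopropyl group or a free amine in place of the isopropylamino group would read. They also leave open whether ethylamino reads the same with iodo in place of chloro.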